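A few compounds are considered here, and "the series" means these few. Any claim that something is new, unique, unknown or untested is made for them only; others in the source may bear on it.

Compound 3 `CCCc1nc(-c2ccccc2)c(CNCCCN2CCN(c3ccc(C(F)(F)F)cc3)CC2)o1` carries a 4-(trifluoromethyl)phenyl on the amine nitrogen in the ring. Among the measured compounds shown here, in an assay on HEK293 cells for inhibition of Voltage-dependent T-type calcium channel subunit alpha-1G (Homo sapiens), read by patch clamp (on this read-out lower numbers stand for stronger inhibition and higher numbers for weaker inhibition), compound 3 gives 7250 nM, the highest of the three numbers measured so far. Compound 2 `CCCc1nc(-c2ccccc2)c(CNCCCN2CCN(c3ccc(F)cc3)CC2)o1` gives 3210 nM in this assay, and compound 1 `CCCc1nc(-c2ccccc2)c(CNCCCN2CCN(c3cccc(C)c3C)CC2)o1` gives 1780 nM. The steps leading to compound 3 both raise the number: a 2.3-fold higher number from compound 2 to compound 3 (0.35 log units; beyond the scatter), and a 4.1-fold higher number from compound 1 to compound 3 (0.61 log units; beyond the scatter).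

Compound 4 `CCCc1nc(-c2ccccc2)c(CNCCCN2CCN(c3ccc(Cl)cc3)CC2)o1` differs from compound 3 in one place: chloro in place of trifluoromethyl on an aromatic carbon. The measured step that bears most on this change is a 2.3-fold higher number from compound 2 to compound 3 (0.35 log units; beyond the scatter), where a single halogen on the same aromatic carbon was exchanged for trifluoromethyl and the number rose modestly. For the measured compounds named here, compound 4 reverses that exchange with a different halogen, so a modest fall in the number, roughly undoing part of that step, is expected, but no measured step covers chloro itself, so the range is kept wide. Compound 4 is therefore estimated at 4500 nM, with a likely range from 2200 nM to 9000 nM, which corresponds to an expected step of a 1.6-fold lower number from compound 3 to compound 4 (0.21 log units; within the scatter).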

Compound 4, half-maximal inhibitory concentration: 1310 nM
Estimate against measurement, compound 4: 3.4-fold (0.54 log units) above; measured number below the stated range.
By their numbers in this assay, from the lowest: compounds 4, 1 and 2 (each within the scatter of the next, the first and the last beyond it); then compound 3.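

In this assay, among the compounds shown here, the group on this aromatic carbon matters more than the earlier compounds showed: the change brings a 5.5-fold lower number from compound 3 to compound 4 (0.74 log units; beyond the scatter), and exchanging one halogen for another brings a 2.5-fold lower number from compound 2 to compound 4 (0.39 log units; beyond the scatter), so fluoro and chloro are not interchangeable here. With a 1.4-fold lower number from compound 1 to compound 4 (0.13 log units; within the scatter), a single chloro on the phenyl ring cannot be told apart from the 2,3-dimethylphenyl group in this assay, which makes the 4-chlorophenyl group a simpler match for that two-methyl ring. No supporting measurement is available to explain why chloro stands apart from fluoro and trifluoromethyl.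

From the compounds shown here alone, whether bromo or methoxy on the same aromatic carbon would follow chloro or trifluoromethyl remains open. The compounds shown also leave open whether the chloro result would hold with a longer chain on the shared core.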